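A few compounds are considered here, and "the series" means these few. Any claim that something is new, unique, unknown or untested is made for them only; others in the source may bear on it.

Measured compounds in a functional assay on NCI-H1993 cells (Homo sapiens) for inhibition, read by CCK-8 assay, with a stated time of 72 h; a lower number here means a stronger inhibitor, a higher number a weaker inhibitor:

compound 1, `Cc1c(C(C)n2cnc3ncc(-c4cn[nH]c4)nc32)ccc2ncccc12`, 599 nM
compound 2, `Cc1c(C(C)n2cnc3ncc(-c4cnn(CCO)c4)nc32)ccc2ncccc12`, 726 nM
compound 3, `c1cnc2ccc(Cn3cnc4ncc(-c5cn[nH]c5)nc43)cc2c1`, 2890 nM

Compound 1 and compound 2 share one core and differ in a single place: 2-hydroxyethyl in place of hydrogen on an aromatic nitrogen. This change produced a 1.2-fold higher number from compound 1 to compound 2 (0.08 log units; within the scatter), so the two values in this assay cannot be told apart. Compound 3 is built on a different core; how the core of compound 3 differs from the core of compound 1 is not broken down here. In this assay compound 3 gives the highest of the three numbers, and its gap to compound 2 as well as to compound 1 lies beyond the scatter.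

Compound 4, `OCCn1cc(-c2cnc3ncn(Cc4ccc5ncccc5c4)c3n2)cn1`, has not yet been measured. It is related to compound 3 by the very change that relates compound 2 to compound 1: 2-hydroxyethyl in place of hydrogen on an aromatic nitrogen. The surroundings of the place are described in identical words for both pairs, so the change is the same one, carried over onto the core of compound 3. Because the earlier step was a 1.2-fold higher number from compound 1 to compound 2 (0.08 log units; within the scatter), the expected step here is also small: the estimate is a 1.2-fold higher number from compound 3 to compound 4 (0.08 log units; within the scatter), starting from the value of compound 3. In this assay compound 4 is therefore expected to give about 3500 nM, with a likely range from 1500 nM to 8000 nM. This expectation rests on a single precedent pair, so the range is kept wide.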

Compound 4, half-maximal inhibitory concentration: 2330 nM
Compound 4: the middle estimate sits 1.5-fold (0.18 log units) above what was measured; low and high end bracket the measured number.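

In this assay, replacing hydrogen with 2-hydroxyethyl on the aromatic nitrogen, which turns 1H-pyrazol-4-yl into 1-(2-hydroxyethyl)-1H-pyrazol-4-yl, gave a 1.2-fold lower number from compound 3 to compound 4 (0.09 log units; within the scatter) and left compound 3 and compound 4 indistinguishable. The same change therefore reads alike on the two cores, with no measurable effect on either one: the same change on two cores in this assay, a 1.2-fold higher number (0.08 log units; within the scatter) from compound 1 to compound 2 and a 1.2-fold lower number (0.09 log units; within the scatter) from compound 3 to compound 4, 1.5-fold (0.18 log units) apart, within the scatter of two such steps. This shows that, in these two pairs, the 2-hydroxyethyl group can be carried from one core to the other without a step that stands out from the scatter, but it rests on just two cores and one cell assay, and so it does not establish a general rule for the series or show that the result would hold on a third core.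

The compounds shown leave open whether other groups on that same nitrogen, such as a methyl, a longer chain like 3-hydroxypropyl, a 2-aminoethyl amine or a carboxylic acid, would also leave the values unchanged. They also leave open which parts of the difference between the core of compound 1 and the core of compound 3 account for the gap between those two compounds, since that difference is not broken down into single changes.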